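Swapping tert-butyl for cyclohexyl at the hydroxy-bearing carbon

A few compounds are considered here, and "the series" means these few. Any claim that something is new, unique, unknown or untested is made for them only; others in the source may bear on it.

Measured compounds:
- compound 1, `CCCC[C@@H](O)C(=O)N1N=CC[C@H]1C(=O)NCc1cc(Cl)ccc1-n1cnnn1`: 9.8 10^-6 cm/s
- compound 2, `O=C(NCc1cc(Cl)ccc1-n1cnnn1)[C@@H]1CC=NN1C(=O)[C@H](O)c1ccccc1F`: 8.9 10^-6 cm/s
- compound 3, `CC(C)(C)[C@@H](O)C(=O)N1N=CC[C@H]1C(=O)NCc1cc(Cl)ccc1-n1cnnn1`: 15 10^-6 cm/s

The three compounds share one core and differ only in the group on a saturated chain carbon bound to a carbonyl carbon and an oxygen on a saturated carbon. In an ADME assay on Caco-2 cells (Homo sapiens) for permeability, read by LC-MS, in the apical to basolateral direction, with a stated time of 60 min, at pH 6.5 (a lower number here means that the compound crosses the layer more slowly, a higher number that the compound crosses the layer faster), compound 3 gives the largest of the three numbers, yet every step to it stays within the scatter: a 1.5-fold higher number from compound 1 to compound 3 (0.18 log units; within the scatter) and a 1.7-fold higher number from compound 2 to compound 3 (0.23 log units; within the scatter). Likewise a 1.1-fold lower number from compound 1 to compound 2 (0.04 log units; within the scatter) shows that butyl and 2-fluorophenyl are not separated by the measurement.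

Compound 4, `O=C(NCc1cc(Cl)ccc1-n1cnnn1)[C@@H]1CC=NN1C(=O)[C@H](O)C1CCCCC1`, has not yet been measured in this assay. Its change from compound 3 is cyclohexyl in place of tert-butyl on a saturated chain carbon bound to a carbonyl carbon and an oxygen on a saturated carbon. The three measured steps all bear on this position, and none of them moved the number beyond the scatter, whether the group was a chain, an aromatic ring or a branched group. On that basis no step beyond the scatter is expected: a 1.2-fold lower number from compound 3 to compound 4 (0.06 log units; within the scatter). Compound 4 is therefore estimated at 13 10^-6 cm/s in this assay, with a likely range from 7 10^-6 cm/s to 24 10^-6 cm/s.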

Compound 4, apparent permeability: 19 10^-6 cm/s
Compound 4: the middle estimate sits 1.5-fold (0.16 log units) below what was measured; low and high end bracket the measured number.
By their numbers in this assay, from the lowest: compounds 2, 1, 3 and 4 (each within the scatter of the next, the first and the last beyond it).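

In this assay this position now gives its first step beyond the scatter: a 2.1-fold higher number from compound 2 to compound 4 (0.33 log units; beyond the scatter). The separation is modest, but it shows that the group here can shift the number measurably, at least between cyclohexyl and 2-fluorophenyl. The other two steps stay within the scatter, a 1.3-fold higher number from compound 3 to compound 4 (0.10 log units; within the scatter) and a 1.9-fold higher number from compound 1 to compound 4 (0.29 log units; within the scatter), so cyclohexyl cannot be told apart from tert-butyl or butyl, and nothing shown gives a reason for the one separated pair.

Going by these compounds, all four groups at this position are carbon groups, with fluorine on the ring of 2-fluorophenyl as the only other element, so the effect of an amine or a carboxylic acid here remains open. Also open, on these data alone, is whether a longer chain or a larger saturated ring would follow cyclohexyl or butyl.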